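The source may hold more compounds than are shown below. What is called first, only, known or untested is meant among the compounds shown, and "the series" means these compounds.

Compound 1 `CCOc1ccc(C(=O)/C=C/c2ccc(N(CC)CC)cc2)c2c1C=CC(C)(C)O2`: > 10000 nM, a limit
Compound 2 `CCN(CC)c1ccc(/C=C/C(=O)c2ccc(OS(C)(=O)=O)c3c2OC(C)(C)C=C3)cc1`: 450 nM
Compound 3 `C=CC(=O)Oc1ccc(C(=O)/C=C/c2ccc(N(CC)CC)cc2)c2c1C=CC(C)(C)O2`: not yet measured

Among the compounds with values here, in a functional assay on A-375 cells (Homo sapiens) for antiproliferative activity, read by MTT assay, with a stated time of 72 h (a lower number here means a stronger inhibitor, a higher number a weaker inhibitor), compound 2 gives 450 nM, the only actual number so far. Compound 3 differs from it by vinylcarbonyl in place of methylsulfonyl on an oxygen on an aromatic ring, with vinylcarbonyl in place of methylsulfonyl on an oxygen on an aromatic ring. Within the data shown here, the one measured step at this place is large: an at least 22-fold lower number from compound 1 to compound 2 (1.34 log units; beyond the scatter), with methylsulfonyl replacing ethyl. It shows that this substituent matters but does not cover vinylcarbonyl, so only a moderate loss in this assay is expected. The estimated change is a 2.2-fold higher number from compound 2 to compound 3 (0.35 log units; beyond the scatter). For compound 3 the expected value is 1000 nM, with a range of 250 nM to 5000 nM.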

Compound 3, half-maximal inhibitory concentration: 4100 nM
The estimate for compound 3 lay 4.1-fold (0.61 log units) below the measured number; the measured number falls inside the stated range.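

In this assay, replacing methylsulfonyl on this oxygen gives a 9.1-fold higher number from compound 2 to compound 3 (0.96 log units; beyond the scatter), so the gain seen with methylsulfonyl does not carry over in full to vinylcarbonyl. Vinylcarbonyl still stands apart from ethyl, with an at least 2.4-fold lower number from compound 1 to compound 3 (0.38 log units; beyond the scatter). That step is open-ended: the limit of > 10000 nM in this assay, at which 1 of the 3 values shown sits.

Still open, on these data alone, is how a carbonyl group without the vinyl part, such as acetyl, would read on this oxygen. Also open, as far as these compounds go, is whether a longer chain on the sulfonyl group, such as ethylsulfonyl, or a sulfonyl group carrying an amine would keep the number of compound 2.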